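The source may report more compounds than this note shows. Statements on the series, on what has been measured and on what is new or still open speak of the compounds shown alone.

Compound 2 `Oc1cccc(-c2ccc3c(-c4ccc5[nH]ccc5c4)c(O)ccc3c2)c1` gives 19% in an assay for binding affinity to 17-beta-hydroxysteroid dehydrogenase type 2 (Homo sapiens), read by scintillation counting, with a stated time of 10 min, tested at 1 uM (on this read-out higher numbers stand for more inhibition at the one concentration tested (going by the name of the read-out) and lower numbers for less inhibition), the lower of the two numbers recorded; its nearest neighbour is compound 1 `Oc1cccc(-c2ccc3c(-c4cncnc4)c(O)ccc3c2)c1`, which gives 85% in the same assay. Compound 3 `Cn1cc(-c2c(O)ccc3cc(-c4cccc(O)c4)ccc23)cn1` has not yet been measured and differs from compound 2 in one place: 1-methyl-1H-pyrazol-4-yl in place of 1H-indol-5-yl on an aromatic carbon. Going by the values given here, the only measured step that bears on this change is a number 66 percentage points lower from compound 1 to compound 2 (beyond the scatter), where a smaller heteroaryl ring was exchanged for the indolyl group. The change from compound 2 to compound 3 runs the other way, removing the indolyl group in favour of a smaller ring with two acceptors, so a sizeable rise in this assay is expected, though the incoming ring is not the same as that in compound 1 and the scatter is wide. Compound 3 is therefore estimated to give 60% (range 30% to 85%), meaning an expected step of a number 41 percentage points higher from compound 2 to compound 3 (beyond the scatter).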

Compound 3, a percentage reported as inhibition, at one concentration (the size of the read-out at that concentration, not a potency): 24%
Compound 3: the middle estimate sits 36 percentage points above what was measured, and the stated range ends above it.
By their numbers in this assay, from the lowest: compounds 2 and 3 (each within the scatter of the next); then compound 1.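

In this assay the replacement of 1H-indol-5-yl by 1-methyl-1H-pyrazol-4-yl gives a number 5 percentage points higher from compound 2 to compound 3 (within the scatter) and so leaves the reading unchanged within the scatter, even though the entering group has fewer heavy atoms and no hydrogen-bond donor. Set against pyrimidin-5-yl, the same group gives a number 61 percentage points lower from compound 1 to compound 3 (beyond the scatter) at this place, on an aromatic carbon ortho to a hydroxy group. Among these three compounds, then, removing the indolyl group is not enough to reach the reading of compound 1, and only the pyrimidin-5-yl compound stands apart. Nothing given here explains why these rings differ. Going by these compounds, it remains open whether a pyridin-3-yl ring, or a 1H-pyrazol-4-yl ring without its methyl, would read closer to compound 1 or to compound 3. On these data alone, because each reading comes from a single concentration, the potencies of all three compounds also remain open.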